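An Acetoxymethyl Replacement Judged Against Two Limits

The compounds below may be only part of what the source reports. "The series", "measured", "known", "first", "only" and "open" are said of these compounds alone.

Compound 1, `CCc1cccc2c(OC)c(-c3occ(C)c3C(=O)NC)ccc12`, was examined in a functional assay on ZR-75-1 cells (Homo sapiens) for cytotoxicity, read by MTT assay, with a stated time of 72 h; a higher number here means that more compound is needed for the effect, a lower number that less compound is needed. In this assay compound 1 reaches only a limit, > 10 ug/mL. Compound 2, `CCc1cccc2c(OC)c(-c3occ(C)c3C(=O)On3nnc4ccccc43)ccc12`, likewise gives no number in this assay but only the limit > 10 ug/mL. The step that the two limits leave unreadable from compound 1 to compound 2 therefore cannot be sized, as the limit of > 10 ug/mL in this assay, at which 2 of the 3 values shown sit, shows. Compound 3, `CCOc1c(-c2occ(C)c2C(=O)OC)ccc2c(CC)cccc12`, differs from compound 1 in more than one place; in this assay compound 3 gives 1.2 ug/mL, a number rather than a limit, so the two values show only that one relative of the core does return a measurable concentration while compound 1 does not.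

Compound 4, `CCc1cccc2c(OC)c(-c3occ(C)c3COC(C)=O)ccc12`, has not yet been measured. It differs from compound 1 by acetoxymethyl in place of methylcarbamoyl on an aromatic carbon. Going by the values given here, no measured step covers this change: the only step on the same carbonyl carbon, from compound 1 to compound 2, lies between two limits and is unreadable, and the result for compound 3 rests on a different set of changes. Compound 1 stands on a limit. The step that this estimate means, an at least 2.0-fold lower number from compound 1 to compound 4 (0.30 log units; that floor lies within the scatter), is therefore expected with caution, toward less compound being needed. Compound 4 is expected to give about 5 ug/mL, within the range 1.5 ug/mL to 15 ug/mL, with a real chance that this assay again reports only a limit.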

Compound 4, concentration for half-maximal effect: 3.5 ug/mL
Compound 4: middle estimate off by 1.4-fold (0.15 log units), on the high side; the measured number falls inside the stated range.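

In this assay, going by these compounds alone, acetoxymethyl in place of methylcarbamoyl on this aromatic carbon gives an at least 2.8-fold lower number from compound 1 to compound 4 (0.45 log units; beyond the scatter), and this is the first readable step at this position. Until now a number had appeared only for compound 3, which differs from compound 1 in more than one place, and the one other step shown cannot be read. The new result shows that a change in this one place alone is enough to turn a limit into a measured concentration on the core of compound 1. The step stays a floor rather than a full size because compound 1 reaches only a limit: the limit of > 10 ug/mL in this assay, at which 2 of the 4 values shown sit.

The compounds shown leave open whether the step depends on the methylcarbamoyl leaving or on the acetoxymethyl entering, and how a hydroxymethyl, an aminomethyl or a carboxylic acid on this aromatic carbon would read in this assay. They also leave open whether a longer chain in the acyl part of the acetoxymethyl would move the number further in either direction, and whether the step would carry over to other cell lines.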